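The source may report more compounds than this note shows. Statements on the series, on what has been measured and on what is new or still open speak of the compounds shown alone.

Measured so far:
- compound 1 `CCCCCCOC(=O)c1cccc(-c2cc(C(=O)Nc3ccncc3)ccc2CN)c1`: 0.833 h
- compound 2 `NCc1ccc(C(=O)Nc2ccncc2F)cc1-c1cccc(C(=O)OCC2CCCCO2)c1`: 0.117 h

In an ADME assay on a cell-free system (plasma, Homo sapiens) for metabolic stability, read by LC-MS (a higher number here means that the compound lasts longer, a lower number that the compound disappears faster), compound 1 stands highest of the two measured compounds at 0.833 h. Compound 2 is its nearest neighbour, and the gap between them lies beyond the scatter.

The next compound to be tested is compound 3 `NCc1ccc(C(=O)Nc2ccncc2)cc1-c1cccc(C(=O)OCC2CCCC2)c1`. Relative to compound 1, it carries cyclopentyl in place of pentyl on a saturated chain carbon bound to an oxygen next to a carbonyl group. Cut one bond further out, the same difference reads hexyloxycarbonyl to cyclopentylmethoxycarbonyl.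

Within the data shown here, no two measured compounds differ in one place only, so the data offer no direct precedent for this change. No step beyond the scatter is therefore expected in this assay, with only a slight lean towards a lower number. The expected change is a 1.4-fold lower number from compound 1 to compound 3 (0.14 log units; within the scatter). The range stays wide on the lower side, as compound 2 reads 0.117 h. For compound 3, the estimated half-life is 0.6 h, with an expected range of 0.2 h to 1.5 h.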

Compound 3, half-life: 0.517 h
Estimate against measurement, compound 3: 1.2-fold (0.06 log units) above; the measured number falls inside the stated range.
By their numbers in this assay, from the lowest: compound 2; then compounds 3 and 1 (each within the scatter of the next).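

In this assay, among these compounds, this is the first pair of compounds that differ in one place, and it gives a 1.6-fold lower number from compound 1 to compound 3 (0.21 log units; within the scatter). Compound 1 and compound 2 differ in more than one place, so they could not isolate any single change; this step shows that, on a saturated chain carbon bound to an oxygen next to a carbonyl group, cyclopentyl in place of pentyl leaves the half-life within the scatter, even though the open chain gives way to a five-membered ring of the same carbon count. The data shown offer no measurement that would explain this outcome.

From the compounds shown here alone, what stays open is how far this tolerance extends at the same place: one pair cannot say whether cyclohexyl, cyclopropyl, a shorter chain such as ethyl or a branched group such as isopropyl would also stay within the scatter of compound 1. Nor do the compounds shown say how the half-life would respond if an amide stood in place of the ester linking these groups to the core of compound 1.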